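This account rests on a few compounds, and the source may have more. Where it says the series, first, only, none or still open, it means among the compounds named here.

Series notes. Compound 1 `Clc1cccc(-c2cc(-c3ccoc3)cc(-c3ccc(Cl)s3)n2)c1` gives 23000 nM in a functional assay on DU-145 cells (Homo sapiens) for cytotoxicity, read by ELISA, with a stated time of 4 days; a lower number here means a stronger inhibitor, a higher number a weaker inhibitor. Compound 2 `Clc1ccc(-c2cc(-c3ccoc3)cc(-c3ccc(Cl)s3)n2)cc1` gives 29500 nM in this assay; the change is 4-chlorophenyl in place of 3-chlorophenyl on an aromatic carbon and the step is a 1.3-fold higher number from compound 1 to compound 2 (0.11 log units; within the scatter). Compound 3 `Cc1ccsc1-c1cc(-c2ccc(Cl)o2)cc(-c2cccc(Cl)c2)n1` gives 20500 nM in this assay; how the core of compound 3 differs from the core of compound 1 is not broken down here, and the two values lie within the scatter of each other.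

Compound 4 `Cc1ccsc1-c1cc(-c2ccc(Cl)o2)cc(-c2ccc(Cl)cc2)n1` is not yet measured. It differs from compound 3 by 4-chlorophenyl in place of 3-chlorophenyl on an aromatic carbon. This is the same kind of change as from compound 1 to compound 2, not the same: there the place was meta to a 5-chlorothiophen-2-yl group and meta to a furan-3-yl group, here it is meta to a 3-methylthiophen-2-yl group and meta to a 5-chlorofuran-2-yl group.

The step from compound 3 to compound 4 is expected to be a 1.3-fold higher number from compound 3 to compound 4 (0.10 log units; within the scatter), because the earlier step of a 1.3-fold higher number from compound 1 to compound 2 (0.11 log units; within the scatter) stayed within the scatter. Compound 4 is therefore estimated at 26000 nM in this assay, with an expected range from 12000 nM to 55000 nM.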

Compound 4, half-maximal inhibitory concentration: 21900 nM
Beside the measured number, compound 4's estimate is 1.2-fold (0.07 log units) above it, and the stated range covers the measured number.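

The step of a 1.1-fold higher number from compound 3 to compound 4 (0.03 log units; within the scatter) in this assay puts the change on a second core, and it does not differ from the earlier step: the same change on two cores in this assay, a 1.3-fold higher number (0.11 log units; within the scatter) from compound 1 to compound 2 and a 1.1-fold higher number (0.03 log units; within the scatter) from compound 3 to compound 4, 1.2-fold (0.08 log units) apart, within the scatter of two such steps.
On these two cores, then, 4-chlorophenyl in place of 3-chlorophenyl leaves the number within the scatter. This does not show a direction for the change or a preference for either chlorophenyl group, and it does not show that the result holds on any other core.

All the compounds shown carry a chlorophenyl group at this place, so an unsubstituted phenyl, or a phenyl bearing an amine or a carboxylic acid, remains open. Going by these compounds, the two cores differ in more than one place, so the separate contributions of their groups also remain open.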